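Removing the ortho fluorine from an anilino quinone core

A few compounds are considered here, and "the series" means these few. Any claim that something is new, unique, unknown or untested is made for them only; others in the source may bear on it.

Of the compounds shown here, three sharing one core have been measured in a functional assay on HeLa cells (Homo sapiens) for inhibition, read by sulforhodamine B assay; on this read-out higher numbers stand for weaker inhibition and lower numbers for stronger inhibition. Compound 1 `O=C1C=C(Nc2ccccc2F)C(=O)c2c1nc1n2[C@H]2OC[C@@H](O)[C@H]2OC1` carries a 2-fluorophenyl group on the amine nitrogen, and in this assay compound 1 gives 5120 nM. Compound 2 `COc1ccc(NC2=CC(=O)c3c(nc4n3[C@H]3OC[C@@H](O)[C@H]3OC4)C2=O)cc1` carries a 4-methoxyphenyl group instead; for compound 2 this assay reports only a limit, > 8000 nM. Compound 3 `COc1cccc(NC2=CC(=O)c3c(nc4n3[C@H]3OC[C@@H](O)[C@H]3OC4)C2=O)c1` carries a 3-methoxyphenyl group; for compound 3 the same assay again reports only a limit, > 8000 nM. The step that the two limits leave unreadable from compound 2 to compound 3 therefore cannot be sized. Among the three values shown, compound 1 has the only number, and the other two sit at the limit of > 8000 nM in this assay, at which 2 of the 3 values shown sit.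

Compound 4 `O=C1C=C(Nc2ccccc2)C(=O)c2c1nc1n2[C@H]2OC[C@@H](O)[C@H]2OC1` has not yet been measured. It differs from compound 1 in one place: hydrogen in place of fluoro on an aromatic carbon. Within the data shown here, none of the measured steps concerns a fluoro-to-hydrogen exchange, so no measured step bears on this change. With compound 1 giving 5120 nM, the expectation is a small step, a 1.4-fold higher number from compound 1 to compound 4 (0.14 log units; within the scatter), within the usual scatter or slightly toward weaker inhibition. Compound 4 is therefore estimated at 7000 nM, with a range from 3000 nM to 16000 nM.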

Compound 4, half-maximal inhibitory concentration: 5620 nM
Estimate against measurement, compound 4: 1.2-fold (0.10 log units) above; the measured number falls inside the stated range.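

In this assay, replacing the fluoro on the aromatic carbon, ortho to a large group, with hydrogen gives a 1.1-fold higher number from compound 1 to compound 4 (0.04 log units; within the scatter). Among these compounds, this is the first pair with a real number on both sides, whereas the earlier compounds offered a single number and two limits, so it gives the first readable measure of a change on this aromatic ring. The 2-fluorophenyl and phenyl compounds cannot be told apart in this assay, which means that this one fluorine, a single heavy atom, makes no measurable difference to inhibition of HeLa cells at this position.

As far as these compounds go, whether a larger replacement at the same place, such as chlorine, a hydroxyl group, an amine or a carboxylic acid, would produce a step beyond the scatter remains open, and a single pair cannot show whether fluoro behaves the same way elsewhere on the ring. Compound 2 and compound 3 carry limits rather than numbers, so how far their methoxy groups weaken inhibition, if they do at all, also stays unknown: the limit of > 8000 nM in this assay, at which 2 of the 4 values shown sit.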